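The source may hold more compounds than are shown below. What is called first, only, known or untested is meant among the compounds shown, and "the series" means these compounds.

Compound 1 `O=[N+]([O-])c1ccc(NC(=S)NCCNS(=O)(=O)c2ccc(-c3ccccc3OCc3ccccc3)s2)cc1` and compound 2 `O=[N+]([O-])c1cccc(NC(=S)NCCNS(=O)(=O)c2ccc(-c3ccccc3OCc3ccccc3)s2)c1` share one core. In a functional assay on RS4-11 cells (Homo sapiens) for inhibition, read by CCK-8 assay, with a stated time of 48 h (a lower number here means a stronger inhibitor, a higher number a weaker inhibitor), compound 1 gives 11300 nM, and compound 2 gives 11600 nM. The change between them, (4-nitrophenyl in place of 3-nitrophenyl on an amide-type nitrogen), made a step of a 1.0-fold lower number from compound 2 to compound 1 (0.01 log units; within the scatter). Compound 3 `COc1ccc(Oc2ccccc2-c2ccsc2S(=O)(=O)N2CCN(C(=O)Nc3cccc([N+](=O)[O-])c3)CC2)cc1OC` is built on a different core, and the difference between the two cores is not broken down here. For compound 3 in this assay only a limit was reported, > 50000 nM, the point where (the limit of > 50000 nM in this assay, at which 1 of the 3 values shown sits). Compound 4 `COc1ccc(Oc2ccccc2-c2ccsc2S(=O)(=O)N2CCN(C(=O)Nc3ccc([N+](=O)[O-])cc3)CC2)cc1OC` is not yet measured; it differs from compound 3 by 4-nitrophenyl in place of 3-nitrophenyl on an amide-type nitrogen, the same kind of change as from compound 2 to compound 1, except that here the amide-type nitrogen has a carbonyl carbon rather than a thiocarbonyl carbon as its other neighbour. Because the step of a 1.0-fold lower number from compound 2 to compound 1 (0.01 log units; within the scatter) stayed within the scatter, compound 4 is expected to shift by about a step that the limit leaves unreadable from compound 3 to compound 4 and most likely to yield again only a limit. Compound 4 is estimated at 60000 nM, between 20000 nM and 200000 nM.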

Compound 4, half-maximal inhibitory concentration: > 50000 nM
Compound 4 was reported as a limit; the forecaster's own chance of this, stated with the estimate: 80%; the middle value lies beyond the limit too.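

Compound 3 and compound 4 are both reported only as limits in this assay, and the step between them cannot be read. The compounds shown leave open whether 4-nitrophenyl in place of 3-nitrophenyl matters at all on the core of compound 3.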